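Stepping the Hydroxycarbamoyl Chain Out from Compound 3

This account rests on a few compounds, and the source may have more. Where it says the series, first, only, none or still open, it means among the compounds named here.

Compound 1 (`Nc1nc2cc(-c3nn(CCCCCCCCCC(=O)NO)c4ncnc(N)c34)ccc2o1`), compound 2 (`Nc1nc2cc(-c3nn(CCC(=O)NO)c4ncnc(N)c34)ccc2o1`) and compound 3 (`Nc1nc2cc(-c3nn(CCCCC(=O)NO)c4ncnc(N)c34)ccc2o1`) share one core and differ in the chain ending in hydroxycarbamoyl. In a functional assay on MCF7 cells (Homo sapiens) for inhibition, read by MTT assay, with a stated time of 72 h (on this read-out lower numbers stand for stronger inhibition and higher numbers for weaker inhibition), compound 1 gives only a limit, > 50000 nM. Compound 2 also gives only a limit, > 100000 nM. Going by the values given here, compound 3 gives 14000 nM, the only actual number of the three. Compound 4 (`Nc1nc2cc(-c3nn(CCCCCC(=O)NO)c4ncnc(N)c34)ccc2o1`) differs from it thus: (hydroxycarbamoyl)methyl in place of hydroxycarbamoyl on a saturated chain carbon, four bonds along the chain from an aromatic nitrogen, with (hydroxycarbamoyl)methyl in place of hydroxycarbamoyl. Among the compounds with values here, two measured steps bear on this change: an at least 7.1-fold lower number from compound 2 to compound 3 (0.85 log units; beyond the scatter), and an at least 3.5-fold lower number from compound 1 to compound 3 (0.55 log units; beyond the scatter). Both fall toward compound 3, and compound 4 stands on the side of compound 1, so a small rise is expected in this assay, probably within the scatter. The expected change is a 1.3-fold higher number from compound 3 to compound 4 (0.11 log units; within the scatter). For compound 4 the estimate is 18000 nM, with an expected range of 6000 nM to 50000 nM.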

Compound 4, half-maximal inhibitory concentration: 12400 nM
Beside the measured number, compound 4's estimate is 1.5-fold (0.16 log units) above it; measured number inside the range.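

In this assay, (hydroxycarbamoyl)methyl in place of hydroxycarbamoyl at this place gives a 1.1-fold lower number from compound 3 to compound 4 (0.05 log units; within the scatter), so these two chain lengths cannot be told apart here. Against the shortest chain there is an at least 8.0-fold lower number from compound 2 to compound 4 (0.90 log units; beyond the scatter), a step that rests on a limit: the limit of > 100000 nM in this assay, at which 1 of the 4 values shown sits. Against the longest chain there is an at least 4.0-fold lower number from compound 1 to compound 4 (0.60 log units; beyond the scatter), which also rests on a limit: the limit of > 50000 nM in this assay, at which 1 of the 4 values shown sits. From the compounds shown here alone, what stays open is whether a carboxylic acid or a primary amide at the chain end would read like the hydroxycarbamoyl group. Also open, going by these compounds, is how chains of intermediate length, longer than that of compound 4 but shorter than that of compound 1, would read.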